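Bromine on a Fused Core and Cell Viability

This account rests on a few compounds, and the source may have more. Where it says the series, first, only, none or still open, it means among the compounds named here.

Measured compounds:
compound 1, `CCCNC(=O)C1CCN(C(=O)c2cc3occc3n2Cc2ccc(OC)cc2)CC1`: 37200 nM
compound 2, `CCCNC(=O)C1CCN(C(=O)c2cc3cc(Br)ccc3n2Cc2ccc(OC)cc2)CC1`: > 100000 nM
compound 3, `CCCNC(=O)C1CCN(C(=O)c2cc3ccccc3n2Cc2ccc(OC)cc2)CC1`: 26000 nM

In an ADME assay on HEK-293T cells (Homo sapiens) for cytotoxicity, read by luminescence and CellTiter-Glo, with a stated time of 24 h (on this read-out higher numbers stand for lower toxicity in this test and lower numbers for higher toxicity in this test), compound 1 gives 37200 nM, and compound 3 gives 26000 nM, the two lying within the scatter of each other. The difference between the two cores is not broken down here. For compound 2 this assay reports only a limit, > 100000 nM, because of the limit of > 100000 nM in this assay, at which 1 of the 3 values shown sits. The step of an at least 3.8-fold higher number from compound 3 to compound 2 (0.58 log units; beyond the scatter) is bromo in place of hydrogen on an aromatic carbon.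

Compound 4, `CCCNC(=O)C1CCN(C(=O)c2cc3oc(Br)cc3n2Cc2ccc(OC)cc2)CC1`, is not yet measured in this assay. Its change from compound 1 is bromo in place of hydrogen on an aromatic carbon. This is the same kind of change, but placed on a five-membered aromatic ring with one oxygen, next to the ring oxygen, rather than on a six-membered aromatic ring of carbon only, meta to a fused ring and para to a fused ring. A step of a 2.7-fold higher number from compound 1 to compound 4 (0.43 log units; beyond the scatter) is expected, resting on the measured step of an at least 3.8-fold higher number from compound 3 to compound 2 (0.58 log units; beyond the scatter). Compound 4 is therefore estimated at 100000 nM, between 40000 nM and 300000 nM.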

Compound 4, half-maximal cytotoxic concentration: 21900 nM
For compound 4 the middle estimate is 4.6-fold (0.66 log units) above the measured one; measured number below the stated range.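

In this assay the bromo group gives a 1.7-fold lower number from compound 1 to compound 4 (0.23 log units; within the scatter), so on the core of compound 1 the change produces no step beyond the scatter. The change therefore did not carry over unchanged from one core to the other in this series: the same change on two cores in this assay, an at least 3.8-fold higher number (0.58 log units; beyond the scatter) from compound 3 to compound 2 and a 1.7-fold lower number (0.23 log units; within the scatter) from compound 1 to compound 4, at least 6.5-fold (0.81 log units) apart, beyond the scatter of two such steps

For the compounds shown here, the value of compound 2, > 100000 nM, is a limit and not a number, and with only one pair on each core, the comparison does not show how the change behaves at other places or on other cores.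

The compounds shown leave open whether a chloro or methyl group on the same aromatic carbon would follow the bromo group on either core. They also leave open what an amine or a carboxylic acid there would do.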